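A chloro substituent on the pyridinylpiperazine side

A few compounds are considered here, and "the series" means these few. Any claim that something is new, unique, unknown or untested is made for them only; others in the source may bear on it.

Three compounds share a core in which a piperazine links a pyridin-2-yl group to an amide. Compound 1 `CCc1cccc(NC(=O)CN2CCN(c3ccccn3)CC2)c1` gives 28.7 nM in a functional assay on cells for agonist activity at D(4) dopamine receptor (Homo sapiens), read by TR-FRET and cAMP accumulation, with a stated time of 30 min; a higher number here means that more compound is needed for the effect, a lower number that less compound is needed. Compound 2 `O=C(CN1CCN(c2ccccn2)CC1)Nc1cccnc1` gives 1080 nM in this assay, and compound 3 `Cc1cccc(NC(=O)CCN2CCN(c3ccccn3)CC2)c1` gives 612 nM. Compound 2 thus holds the highest number of the three; its gap to compound 3 lies within the scatter, while its gap to compound 1 is large, as the step of a 38-fold higher number from compound 1 to compound 2 (1.58 log units; beyond the scatter) shows, which replaces 3-ethylphenyl with pyridin-3-yl on the amide nitrogen.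

Compound 4 `O=C(CN1CCN(c2ccc(Cl)cn2)CC1)Nc1cccnc1` differs from compound 2 elsewhere: chloro in place of hydrogen on an aromatic carbon, on an aromatic carbon of the six-membered aromatic ring with one nitrogen, two atoms from the ring nitrogen, para to a large group, so that pyridin-2-yl becomes 5-chloropyridin-2-yl. Among the compounds with values here, no measured step touches this ring, so the single known step gives no guide here. In the absence of such a guide, the expectation is a step of a 1.4-fold lower number from compound 2 to compound 4 (0.13 log units; within the scatter) that stays within the scatter, and compound 4 is therefore estimated at 800 nM, with a range from 200 nM to 3200 nM.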

Compound 4, half-maximal effective concentration: "not active" (no number reported)
No number was reported for compound 4; no gap can be computed for the estimate.
By their numbers in this assay, from the lowest: compound 1; then compounds 3 and 2 (each within the scatter of the next).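

Within the data shown here, compound 4 is recorded as "not active" with no number, so no step from compound 2 to compound 4 can be read. No evidence here explains this result. The compounds shown leave open whether 5-chloropyridin-2-yl would give a number alongside the 3-ethylphenyl amide of compound 1.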